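Methyl in place of hydrogen: expected exposure of compound 3

This account rests on a few compounds, and the source may have more. Where it says the series, first, only, none or still open, it means among the compounds named here.

Compounds measured so far in an ADME assay on the whole organism (strain Sprague-Dawley) for pharmacokinetics, with Rattus norvegicus as the target, read by LC-MS, at a dose of 10 mg/kg by the oral route (on this read-out lower numbers stand for lower exposure and higher numbers for higher exposure at the dose given), are these:
compound 1 (`CC#C[C@@H](CC(=O)O)c1ccc(OC[C@H]2COc3ccc(Cl)cc3O2)cc1`) gives 656000 ng.h/mL
compound 2 (`CC#C[C@@H](CC(=O)O)c1ccc(OC[C@H]2COc3ccccc3O2)cc1`) gives 275000 ng.h/mL

Among the compounds with values here, compound 2 holds the lower of the two numbers in this assay and its only neighbour is compound 1. Within the data shown here, the single measured step is a 2.4-fold lower number from compound 1 to compound 2 (0.38 log units; beyond the scatter) with hydrogen in place of chloro on an aromatic carbon, a modest change.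

Compound 3 (`CC#C[C@@H](CC(=O)O)c1ccc(OC[C@H]2COc3ccc(C)cc3O2)cc1`) follows from compound 2 with methyl in place of hydrogen on an aromatic carbon. Among the measured compounds shown here, the step from chloro to hydrogen is the only measurement that bears on this change, and it concerns another group, so the evidence is thin. Read in reverse, a 2.4-fold lower number from compound 1 to compound 2 (0.38 log units; beyond the scatter) suggests that a group entering on an aromatic carbon may raise the number. For the measured compounds named here, no methyl compound has been measured, so a smaller move in the same direction is expected, and it may not clear the scatter. The expected size is a 1.4-fold higher number from compound 2 to compound 3 (0.14 log units; within the scatter) for this change.

For compound 3 the estimated value is 380000 ng.h/mL with an expected range from 170000 ng.h/mL to 800000 ng.h/mL in this assay at the dose given.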

Compound 3, area under the concentration-time curve: 65200 ng.h/mL
The estimate for compound 3 lay 5.8-fold (0.77 log units) above the measured number; measured number outside the range, below it.
By their numbers in this assay, from the lowest: compound 3; then compound 2; then compound 1.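

Methyl and chloro do not act alike on this aromatic carbon. In this assay, methyl in place of hydrogen brings a 4.2-fold lower number from compound 2 to compound 3 (0.63 log units; beyond the scatter) in this series, while chloro stands on the higher side of hydrogen, so the two groups move the number in opposite directions from the same parent, and a group entering here cannot be assumed to raise exposure. Exchanging one group for the other gives a 10-fold lower number from compound 1 to compound 3 (1.00 log units; beyond the scatter) at this single position, a wider gap than either group shows against hydrogen, so the identity of the group matters at least as much as its presence, and no evidence at hand accounts for this split between methyl and chloro.

Three compounds cannot show whether other groups on this carbon, such as fluoro, methoxy or nitrile, would follow chloro or methyl, or whether exposure tracks any single feature of the group. From the compounds shown here alone, it also remains open whether methyl and chloro would part in the same way on the other carbons of this six-membered aromatic ring, or at a different oral dose.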